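A few compounds are considered here, and "the series" means these few. Any claim that something is new, unique, unknown or untested is made for them only; others in the source may bear on it.

Compound 1 `COc1ccc(S(=O)(=O)Nc2ccc(-c3nc4ccccc4o3)cc2)cc1` carries the shared core, and in an assay on cells for inhibition of HSP60/HSP10 (Homo sapiens), with a stated time of 60 min (a lower number here means a stronger inhibitor, a higher number a weaker inhibitor), compound 1 reaches only a limit of the assay, > 100000 nM. Compound 3 `O=S(=O)(Nc1ccc2oc(-c3ccccc3)nc2c1)c1ccccc1Cl` likewise ends at a limit in this assay, > 100000 nM. Compound 2 `CS(=O)(=O)Nc1ccc(-c2nc3cc(NS(=O)(=O)c4ccc(Cl)s4)ccc3o2)cc1` gives a number in this assay, 43000 nM. Compound 1 therefore stands at the limit where two of the three values sit (the limit of > 100000 nM in this assay, at which 2 of the 3 values shown sit), and the numbers shown place it no lower than any other compound. Compound 4 `C=Cc1ccc(S(=O)(=O)Nc2ccc(-c3nc4ccccc4o3)cc2)cc1` differs from compound 1 by vinyl in place of methoxy on an aromatic carbon. Among the compounds with values here, no measured pair shows this change, so no step beyond the scatter is expected in this assay. Compound 4 is estimated at 150000 nM, between 50000 nM and 500000 nM, a step that the limit leaves unreadable from compound 1 to compound 4 expected to stay within the scatter.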

Compound 4, half-maximal inhibitory concentration: > 100000 nM
Compound 4 was reported as a limit (the forecaster's own chance of this, stated with the estimate: 80%); the middle value is on the limit's open side.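

Within the data shown here, compound 1 and compound 4 both end at a limit in this assay, so no step between them can be read. The compounds shown leave open whether vinyl in place of methoxy changes inhibition at all.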